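Amide to urea on a cell-growth series

The source may report more compounds than this note shows. Statements on the series, on what has been measured and on what is new or still open speak of the compounds shown alone.

Of the compounds shown here, three sharing one core have been tested in a functional assay on SF-539 cells (Homo sapiens) for inhibition, read by sulforhodamine B assay, with a stated time of 48 h; on this read-out higher numbers stand for weaker inhibition of growth and lower numbers for stronger inhibition of growth. Compound 1, `COc1cc(-c2nn(-c3cccc(NC(=O)c4ccc(Cl)c(C(F)(F)F)c4)c3)cc2-c2ccncc2)ccc1Cl`, gives 20300 nM in this assay, the highest of the three numbers. Compound 2, `COc1cc(-c2nn(-c3cccc(NC(=O)c4cccc(C(F)(F)F)c4)c3)cc2-c2ccncc2)ccc1Cl`, gives 2300 nM, and compound 3, `COc1cc(-c2nn(-c3cccc(NC(=O)Nc4cccc(C(F)(F)F)c4)c3)cc2-c2ccncc2)ccc1Cl`, gives 2420 nM. The step of an 8.8-fold lower number from compound 1 to compound 2 (0.95 log units; beyond the scatter) and the step of an 8.4-fold lower number from compound 1 to compound 3 (0.92 log units; beyond the scatter) both move beyond the scatter, while the step of a 1.1-fold higher number from compound 2 to compound 3 (0.02 log units; within the scatter) stays within it.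

Compound 4, `COc1cc(-c2nn(-c3cccc(NC(=O)Nc4ccc(Cl)c(C(F)(F)F)c4)c3)cc2-c2ccncc2)ccc1Cl`, has not yet been measured. It differs from compound 1 in one place: (4-chloro-3-(trifluoromethyl)phenyl)amino in place of 4-chloro-3-(trifluoromethyl)phenyl on a carbonyl carbon. The carbonyl carbon that receives the new group keeps its amide-type nitrogen neighbour, so the link becomes a urea in place of an amide.

The step that bears most directly on this change is a 1.1-fold higher number from compound 2 to compound 3 (0.02 log units; within the scatter), which is the same amide-to-urea exchange on the ring lacking chloro and shows no movement beyond the scatter. The chloro itself is kept, so the large step of an 8.8-fold lower number from compound 1 to compound 2 (0.95 log units; beyond the scatter) should not apply. Compound 4 is therefore expected to sit close to compound 1, with a step of a 1.3-fold lower number from compound 1 to compound 4 (0.10 log units; within the scatter) that is within the scatter, giving an estimate of 16000 nM, with a range from 5000 nM to 50000 nM.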

Compound 4, concentration for total growth inhibition: 6340 nM
Beside the measured number, compound 4's estimate is 2.5-fold (0.40 log units) above it; the measured number falls inside the stated range.
By their numbers in this assay, from the lowest: compounds 2 and 3 (each within the scatter of the next); then compound 4; then compound 1.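

In this assay, the exchange of amide for urea turns out to matter when the chloro is present, with a 3.2-fold lower number from compound 1 to compound 4 (0.51 log units; beyond the scatter), whereas the same exchange on the ring lacking chloro gave a 1.1-fold higher number from compound 2 to compound 3 (0.02 log units; within the scatter). On the urea link, the chloro-bearing compound still gives the higher number, with a 2.6-fold higher number from compound 3 to compound 4 (0.42 log units; beyond the scatter), and the comparison across both changes gives a 2.8-fold higher number from compound 2 to compound 4 (0.44 log units; beyond the scatter), so compound 4 does not reach the level of compounds 2 and 3. The chloro therefore weakens growth inhibition on both links, but the size of that loss depends on the link, and it is smaller on the urea than on the amide: the same change on two cores in this assay, an 8.8-fold lower number (0.95 log units; beyond the scatter) from compound 1 to compound 2 and a 2.6-fold lower number (0.42 log units; beyond the scatter) from compound 4 to compound 3, 3.4-fold (0.53 log units) apart, beyond the scatter of two such steps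

As far as these compounds go, these compounds carry only chloro or hydrogen at this place on the ring, so how a fluoro or a methyl group would behave on either link remains open, as does the effect of a carbamate in place of the amide or urea. Within the data shown here, with only two links and two ring substituents in a single cell line, it also remains unknown whether this dependence of the chloro step on the link extends to other groups or to other cells.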